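From compound 1 to compound 4: one chain swapped

The compounds below may be only part of what the source reports. "The series", "measured", "known", "first", "only" and "open" are said of these compounds alone.

Measured in an ADME assay on S9 fraction from liver (Rattus norvegicus), read by LC-MS, with a stated time of 60 min, at 37 degrees C; on this read-out lower numbers stand for a less stable compound and higher numbers for a more stable compound
Compound 1 `CC(C)C(=O)OCOC(=O)N1CCN(C(=O)c2nc(Nc3cc(C4CC4)[nH]n3)c3cc(Cl)ccc3n2)C[C@H]1C` gives 14%
Compound 2 `CCCCCOC(=O)N1CCN(C(=O)c2nc(Nc3cc(C4CC4)[nH]n3)c3cc(Cl)ccc3n2)C[C@H]1C` gives 63.9%
Compound 3 `CC(OC(=O)C(C)C)OC(=O)N1CCN(C(=O)c2nc(Nc3cc(C4CC4)[nH]n3)c3cc(Cl)ccc3n2)C[C@H]1C` gives 11%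

Compound 1 sits in the low group of this small set, together with compound 3 in a number 3 percentage points lower from compound 1 to compound 3 (within the scatter). That step, methyl in place of hydrogen, does not resemble the change considered here.

Compound 4 `C[C@@H]1CN(C(=O)c2nc(Nc3cc(C4CC4)[nH]n3)c3cc(Cl)ccc3n2)CCN1C(=O)OCC(Cl)(Cl)Cl` has not been measured. It differs from compound 1 by one swap: trichloromethyl in place of (isopropylcarbonyl)oxy on a saturated chain carbon bound to an oxygen next to a carbonyl group. The same group leaves at the same place on the way to compound 2, where butyl enters instead. That makes a number 49.9 percentage points higher from compound 1 to compound 2 (beyond the scatter) the closest guide, and a number 52.9 percentage points lower from compound 2 to compound 3 (beyond the scatter) shows the same gap from the other side. Going by the values given here, no measured compound carries trichloromethyl, so butyl is only an imperfect stand-in and the range must stay wide. A large upward move is still expected in this assay.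

The estimated change is a number 41 percentage points higher from compound 1 to compound 4 (beyond the scatter).

For compound 4 the expected value is 55%, with an estimated range from 30% to 80%.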

Compound 4, percent of the compound remaining: 78.9%
Compound 4: middle estimate off by 23.9 percentage points, on the low side; the range from low to high includes it.
By their numbers in this assay, from the lowest: compounds 3 and 1 (each within the scatter of the next); then compound 2; then compound 4.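

In this assay, replacing (isopropylcarbonyl)oxy with trichloromethyl at this saturated chain carbon gives a number 64.9 percentage points higher from compound 1 to compound 4 (beyond the scatter), a larger rise than butyl gave at the same place. The incoming group therefore matters as well as the one that leaves: with (isopropylcarbonyl)oxy gone from both compounds, the change is still a number 15 percentage points higher from compound 2 to compound 4 (beyond the scatter), so trichloromethyl and butyl are not interchangeable here. The widest contrast among these compounds is a number 67.9 percentage points higher from compound 3 to compound 4 (beyond the scatter), which places the 2,2,2-trichloroethyl carbamate at the stable end of the set and the 1-((isopropylcarbonyl)oxy)ethyl compound at the unstable end.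

Nothing shown here explains why these compounds differ. As far as these compounds go, it also remains open how trifluoromethyl, a single chlorine or a longer chain would behave at this carbon, so the result cannot yet be tied to the chlorines or to the chain itself.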